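From chloro to bromo on the shared core

The source may report more compounds than this note shows. Statements on the series, on what has been measured and on what is new or still open speak of the compounds shown alone.

Compound 1 `CC1(C)CC(NC(=O)NCc2ccccc2)c2cc(Br)ccc2O1` gives 27000 nM
Compound 2 `CC1(C)CC(NC(=O)Nc2ccccc2Cl)c2cc(Br)ccc2O1` gives 19000 nM
Compound 3 `CC1(C)CC(NC(=O)Nc2ccc(Cl)cc2)c2cc(Cl)ccc2O1` gives 19000 nM

In a functional assay on U-373MG ATCC cells (Homo sapiens) for inhibition, read by MTT assay, with a stated time of 72 h (on this read-out lower numbers stand for stronger inhibition and higher numbers for weaker inhibition), compound 3 stands level with compound 2, and compound 1 lies within the usual scatter of both. The change to compound 4 `CC1(C)CC(NC(=O)Nc2ccc(Cl)cc2)c2cc(Br)ccc2O1` is bromo in place of chloro on an aromatic carbon and it puts bromo in place of chloro on an aromatic carbon. For the measured compounds named here, no measured pair shows this swap alone. Going by the values given here, the only measured step is a 1.4-fold lower number from compound 1 to compound 2 (0.15 log units; within the scatter) and it lies elsewhere on the molecule. Compound 2 at 19000 nM carries bromo on the shared core and sits level with compound 3, though the two also differ elsewhere. The expected step in this assay is therefore no change at the digits printed from compound 3 to compound 4 (within the scatter) and stays within the scatter. For compound 4 the estimate is 19000 nM with an expected range of 10000 nM to 35000 nM.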

Compound 4, half-maximal inhibitory concentration: 25000 nM
Compound 4: the middle estimate sits 1.3-fold (0.12 log units) below what was measured, and the stated range covers the measured number.
By their numbers in this assay, from the lowest: compounds 2, 3, 4 and 1 (each within the scatter of the next).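

The bromo-for-chloro swap now has a measured pair of its own, and in this assay it gives a 1.3-fold higher number from compound 3 to compound 4 (0.12 log units; within the scatter). On the amide-type nitrogen, 4-chlorophenyl in place of 2-chlorophenyl gives a 1.3-fold higher number from compound 2 to compound 4 (0.12 log units; within the scatter), and 4-chlorophenyl in place of benzyl gives a 1.1-fold lower number from compound 1 to compound 4 (0.03 log units; within the scatter), so none of these three changes separates the compounds. No further evidence on these results is available. Going by these compounds, what stays open is whether an amine or a carboxylic acid on that aromatic carbon, in place of the halogen, would give a step beyond the scatter.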